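The source may hold more compounds than are shown below. What is called first, only, known or untested is meant among the compounds shown, and "the series" means these compounds.

Compound 1, `CC1CCN(C2CCN(S(=O)(=O)c3cccc(C(F)(F)F)c3)CC2)CC1`, gives > 5000 nM in a functional assay on DLD-1 cells (Homo sapiens) for antiproliferative activity, read by CellTiter-Glo, with a stated time of 72 h (a lower number here means a stronger inhibitor, a higher number a weaker inhibitor), which is a limit of the assay rather than a number.
Compound 2, `CC1CCN(C2CCN(S(=O)(=O)c3cccc(-c4ccccc4F)c3)CC2)CC1`, gives 10 nM in this assay.
Compound 3, `CC1CCN(C2CCN(S(=O)(=O)c3cccc(Cl)c3)CC2)CC1`, gives > 5000 nM in this assay, again a limit and not a number.

Among these three, compound 3 sits at the limit of > 5000 nM in this assay, at which 2 of the 3 values shown sit, so its true number is known only to lie beyond that limit. Compound 4, `CC1CCN(C2CCN(S(=O)(=O)c3cccc(-c4ccccc4)c3)CC2)CC1`, has not yet been measured; it differs from compound 3 by phenyl in place of chloro on an aromatic carbon. The measured step closest to this one is an at least 500-fold higher number from compound 2 to compound 3 (2.69 log units; beyond the scatter), which runs the opposite way: exchanging the 2-fluorophenyl for chloro pushed the number past the limit. The step of an at least 500-fold lower number from compound 1 to compound 2 (2.69 log units; beyond the scatter), where 2-fluorophenyl enters in place of trifluoromethyl, points the same way, with the aromatic group tied to a far lower number. Restoring an aromatic ring, here phenyl without fluorine, is therefore expected to bring a large step to a lower number, an at least 250-fold lower number from compound 3 to compound 4 (2.39 log units; beyond the scatter). Compound 4 is expected to give 20 nM in this assay, within 5 nM to 100 nM.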

Compound 4, half-maximal inhibitory concentration: 2 nM
Estimate against measurement, compound 4: 10-fold (1.00 log units) above; measured number below the stated range.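

Removing the fluorine from the added ring does not weaken the compound at this position on the aromatic ring; instead it gives a 5.0-fold lower number from compound 2 to compound 4 (0.70 log units; beyond the scatter), so a plain phenyl group is enough for the low number. In this assay, the same phenyl group gives an at least 2500-fold lower number from compound 3 to compound 4 (3.39 log units; beyond the scatter) when it replaces chloro and an at least 2500-fold lower number from compound 1 to compound 4 (3.39 log units; beyond the scatter) when it replaces trifluoromethyl. Both sizes are only minimum figures because compound 1 and compound 3 each rest on a limit of the assay, not a number: the limit of > 5000 nM in this assay, at which 2 of the 4 values shown sit.

The compounds shown leave open whether an aromatic ring is required here, or whether a cyclohexyl ring in the same place would serve as well. On these data alone, it also remains unknown how a pyridyl ring, or an amine or carboxylic acid carried on the phenyl ring, would change the number.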